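A Fluorine Added to the Core of Compound 1

The compounds below may be only part of what the source reports. "The series", "measured", "known", "first", "only" and "open" are said of these compounds alone.

Compound 1, `Cc1cccc(N2CCN(CCCNc3nc(NCc4ccco4)c4ccccc4n3)CC2)c1C`: 91.5%
Compound 2, `Fc1ccc2nc(NCCCCN3CCN(c4cccc(Cl)c4Cl)CC3)nc(NCc3ccco3)c2c1`: 95.5%

Of the compounds shown here, two have been measured in a functional assay on DU-145 cells (Homo sapiens) for cytotoxicity, read by MTT assay, with a stated time of 2 days, tested at 10 uM; a lower number here means less inhibition, a higher number more inhibition at the concentration tested (going by the name of the read-out). In this assay compound 1 gives 91.5%, the lower of the two numbers shown, while compound 2 gives 95.5%. The gap between them lies within the usual scatter of repeated measurements, so the two cannot be told apart on this evidence. Compound 2 also differs from compound 1 in several places at once, so its number says nothing about any single change.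

Compound 3, `Cc1cccc(N2CCN(CCCNc3nc(NCc4ccco4)c4cc(F)ccc4n3)CC2)c1C`, has not yet been measured. It differs from compound 1 in one place only: fluoro in place of hydrogen on an aromatic carbon. For the measured compounds named here, no measured pair shows what this change does on its own. Since both measured numbers are high and close to each other, the expected step is a number 0.5 percentage points higher from compound 1 to compound 3 (within the scatter), none beyond the scatter. Compound 3 is therefore expected to give 92% in this assay. For compound 3 the expected range runs from 82% to 98%.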

Compound 3, a percentage reported as inhibition, at one concentration (the size of the read-out at that concentration, not a potency): 95.9%
Compound 3: the middle estimate sits 3.9 percentage points below what was measured; the range from low to high includes it.
By their numbers in this assay, from the lowest: compounds 1, 2 and 3 (each within the scatter of the next).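

For the compounds shown here, this is the first direct reading of what adding a fluoro group to the shared core does: in this assay the change gives a number 4.4 percentage points higher from compound 1 to compound 3 (within the scatter). At this position, then, compound 1 and compound 3 cannot be told apart, so with the single added fluorine atom the number stays level at the one concentration tested. No other measurement bears on this result, so the data offer no account of how this fluoro group acts in these cells.

Going by these compounds, whether this carbon accepts anything other than fluoro stays open: a larger group such as methoxy, an amine or a carboxylic acid at the same place could keep the number high or lower it, and only such a compound would show how much room the position allows. Also open, on these data alone, is what a true potency measure would show, since readings taken at a single concentration and this close to the top of the scale could hide a real difference between compound 1 and compound 3.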